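Series notes: a hydroxy on the linker chain of compound 1

A few compounds are considered here, and "the series" means these few. Any claim that something is new, unique, unknown or untested is made for them only; others in the source may bear on it.

Measured so far, in an assay on HEK293 cells for displacement of a labelled ligand from 5-hydroxytryptamine receptor 7 (Homo sapiens), read by scintillation counting, with a stated time of 1 h; a higher number here means a weaker inhibitor, a lower number a stronger inhibitor:
- compound 1 `O=S(=O)(NC1CCN(CCCOc2ccccc2-c2ccccc2)CC1)c1cccc(Cl)c1` gives 52 nM
- compound 2 `O=S(=O)(NC1CCN(CCCOc2ccccc2-c2ccccc2)CC1)c1ccc(F)cc1` gives 58 nM

Compound 1 has the lowest of the two numbers. Its nearest neighbour is compound 2, and the step of a 1.1-fold higher number from compound 1 to compound 2 (0.05 log units; within the scatter) lies within the scatter, so the two compounds cannot be told apart on these data; the exchange of the aryl group on the sulfonyl sulfur leaves the read-out where it was.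

Compound 3 `O=S(=O)(NC1CCN(CC(O)COc2ccccc2-c2ccccc2)CC1)c1cccc(Cl)c1` is not yet measured. It differs from compound 1 in a single place: hydroxy in place of hydrogen on a saturated chain carbon bound to two saturated chain carbons. Among the compounds with values here, the only measured step, from compound 1 to compound 2, concerns the aryl group on the sulfonyl sulfur and leaves the chain untouched, so no measured step bears on a change at this position. Within the data shown here, what the hydroxy does to the number is therefore open in both directions, and the expectation rests on the size of the one step that is known, which was small.

On that basis compound 3 is expected to show a step of a 1.5-fold higher number from compound 1 to compound 3 (0.19 log units; within the scatter) in this assay, with a wide range because no chain change has been measured. The estimate for compound 3 is 80 nM, from 25 nM to 260 nM.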

Compound 3, inhibition constant: 33 nM
For compound 3 the middle estimate is 2.4-fold (0.38 log units) above the measured one, within the range that was stated.
By their numbers in this assay, from the lowest: compounds 3, 1 and 2 (each within the scatter of the next).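

In this assay, hydroxy in place of hydrogen on a saturated chain carbon bound to two saturated chain carbons gives a 1.6-fold lower number from compound 1 to compound 3 (0.20 log units; within the scatter), so compound 3 and compound 1 cannot be told apart on these data. Within the data shown here, the earlier pair spoke only to the aryl group on the sulfonyl sulfur, whereas this pair gives the first reading on the linker chain: this position takes a hydroxy, with its one hydrogen-bond donor and one hydrogen-bond acceptor, without a separable shift in the read-out. Nothing available accounts for this outcome or links it to any property of the hydroxy.

Still open, from the compounds shown here alone, is whether this position stays as permissive for other groups on the same chain carbon, such as a methoxy, an amine or a carboxylic acid, since a single hydroxy cannot show how far that tolerance extends. Also open, going by these compounds, is whether the hydroxy gives a similar reading alongside the 4-fluorophenyl group of compound 2, and whether a longer chain carrying the hydroxy stays within the same range.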